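The compounds below may be only part of what the source reports. "The series", "measured", "known", "first", "only" and "open" are said of these compounds alone.

Measured so far:
Compound 1, `NCCNc1cc(N2CCCc3ccccc3C2)nc2ccc(Cl)cc12`: its value in an ADME assay on HEp-2 cells (Homo sapiens) for cytotoxicity, read by CCK-8 assay, with a stated time of 5 days (on this read-out higher numbers stand for lower toxicity in this test and lower numbers for higher toxicity in this test), is a limit, > 3200 nM.
Compound 2, `Cc1ccc2nc(N3CCCc4ccccc4C3)cc(NCCN)c2c1`: in this assay compound 2 gives 9400 nM.

Going by the values given here, compound 2 holds the only number in this assay. The other value, that of compound 1, is a limit, (the limit of > 3200 nM in this assay, at which 1 of the 2 values shown sits). That limit leaves the step that the limit leaves unreadable from compound 1 to compound 2 unreadable. Compound 3, `NCCNc1cc(N2CCCc3ccccc3C2)nc2ccc(C(F)(F)F)cc12`, differs from compound 2 by trifluoromethyl in place of methyl on an aromatic carbon. No readable measured step bears on this exchange, so the expected step of a 1.3-fold lower number from compound 2 to compound 3 (0.13 log units; within the scatter) in this assay is taken as none beyond the usual scatter. Compound 3 is accordingly estimated at 7000 nM, within 2500 nM to 20000 nM.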

Compound 3, half-maximal cytotoxic concentration: 6700 nM
The estimate for compound 3 lay 1.0-fold (0.02 log units) above the measured number, within the range that was stated.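

In this assay, going by these compounds alone, trifluoromethyl in place of methyl gives a 1.4-fold lower number from compound 2 to compound 3 (0.15 log units; within the scatter), the first readable step at this position, so the two groups cannot be told apart on this read-out. Trifluoromethyl counts 4 heavy atoms against 1 for methyl, yet the two values remain within the scatter of each other. Compound 1 still holds only a limit, and the steps from it cannot be read: the limit of > 3200 nM in this assay, at which 1 of the 3 values shown sits.

Going by these compounds, whether an amine or a carboxylic acid at this position would move the number beyond the scatter stays open. So does the outcome of a longer chain in place of the one the three compounds share.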